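Moving the Trifluoromethyl Group: What Compound 4 May Show

The source may report more compounds than this note shows. Statements on the series, on what has been measured and on what is new or still open speak of the compounds shown alone.

Compound 1 `CC(C)c1ccc(-n2nc(-c3ccc(C(F)(F)F)cc3O)nc2-c2ccccc2O)cc1`: 108%
Compound 2 `Oc1cc(C(F)(F)F)ccc1-c1nc(-c2ccccc2O)n(-c2ccc(C(F)(F)F)cc2)n1`: 102%
Compound 3 `Oc1cc(C(F)(F)F)ccc1-c1nc(-c2ccccc2O)n(-c2ccc(OC(F)(F)F)cc2)n1`: 92.5%

These three numbers come from a functional assay on PC-12 cells (Rattus norvegicus) for cytotoxicity, read by MTT assay, with stated times of 2 h and 24 h, tested at 10 uM (on this read-out lower numbers stand for a weaker effect and higher numbers for a stronger effect at the one concentration tested), in which compound 1 gives 108%, compound 2 gives 102% and compound 3 gives 92.5%. The compounds share one core and differ only in the group carried on the aromatic ring that sits on the five-membered ring. The step of a number 6 percentage points lower from compound 1 to compound 2 (within the scatter) and the step of a number 9.5 percentage points lower from compound 2 to compound 3 (within the scatter) are both within the scatter, so the number for compound 2 is not separated from that of compound 1 or of compound 3; only the longer step of a number 15.5 percentage points lower from compound 1 to compound 3 (beyond the scatter) reaches beyond the scatter, and even that is modest.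

Compound 4 `Oc1cc(C(F)(F)F)ccc1-c1nc(-c2ccccc2O)n(-c2cccc(C(F)(F)F)c2)n1` is a rearrangement of compound 2: 3-(trifluoromethyl)phenyl in place of 4-(trifluoromethyl)phenyl on an aromatic nitrogen. Going by the values given here, none of the measured steps moves a group from one place on this ring to another; each of them exchanges one group for another, and two of the three stay within the scatter. On that basis the step to compound 4 is expected to be small, a number 2 percentage points lower from compound 2 to compound 4 (within the scatter), with no change beyond the scatter. Compound 4 is therefore estimated at 100%, in the range 85% to 115%.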

Compound 4, a percentage reported as activity, at one concentration (the size of the read-out at that concentration, not a potency): 99.9%
Estimate against measurement, compound 4: 0.1 percentage points above; low and high end bracket the measured number.
By their numbers in this assay, from the lowest: compounds 3, 4, 2 and 1 (each within the scatter of the next, the first and the last beyond it).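

In this assay, going by these compounds alone, putting 3-(trifluoromethyl)phenyl in place of 4-(trifluoromethyl)phenyl on the aromatic nitrogen gives a number 2.1 percentage points lower from compound 2 to compound 4 (within the scatter) and is the first change in this set that keeps the group and alters only where it sits on the ring, and the two placements are not separated in this read-out. Compound 4 is not separated from the other two compounds either, with a number 7.4 percentage points higher from compound 3 to compound 4 (within the scatter) and a number 8.1 percentage points lower from compound 1 to compound 4 (within the scatter) both printed as within the scatter, even though compound 1 and compound 3 do stand apart from each other, so the new placement adds a compound that falls inside the narrow span of the series without widening it. No measurement to hand offers an explanation for this result or bears on it.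

The compounds shown leave open whether a group of another kind, such as an amine or a carboxylic acid, would give a number beyond the scatter when carried on this ring in either of the two placements. They also leave open whether the placement of the trifluoromethyl group matters at any concentration other than the single one tested in this assay or in any other read-out.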